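A dichlorophenyl anilide on the chloro nitrobenzoate core

The source may hold more compounds than are shown below. What is called first, only, known or untested is meant among the compounds shown, and "the series" means these compounds.

Measured so far in a functional assay on HepG2 cells (Homo sapiens), read by MTT assay, with a stated time of 72 h; a higher number here means a weaker inhibitor, a lower number a stronger inhibitor:
compound 1, `O=C(Oc1ccc(Cl)cc1C(=O)Nc1ccc(C(F)(F)F)cc1)c1ccc([N+](=O)[O-])cc1`: 1150 nM
compound 2, `O=C(Oc1ccc(Br)cc1C(=O)Nc1ccc(C(F)(F)F)cc1)c1ccc([N+](=O)[O-])cc1`: 1250 nM
compound 3, `O=C(Oc1ccc(Cl)cc1C(=O)Nc1ccc(C(F)(F)F)cc1)c1ccc(Br)cc1`: 14500 nM

Compound 1 gives the lowest of the three numbers in this assay. Compound 2 stands nearest to it: a 1.1-fold higher number from compound 1 to compound 2 (0.04 log units; within the scatter), so the two are not told apart. Compound 3 stands furthest: a 13-fold higher number from compound 1 to compound 3 (1.10 log units; beyond the scatter), a large loss.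

Compound 4, `O=C(Oc1ccc(Cl)cc1C(=O)Nc1ccc(Cl)c(Cl)c1)c1ccc([N+](=O)[O-])cc1`, has not yet been measured. It differs from compound 1 in one place: 3,4-dichlorophenyl in place of 4-(trifluoromethyl)phenyl on an amide-type nitrogen. Neither measured step touches this part of the molecule. The step from compound 1 to compound 2 swaps one group on the shared core, and the step from compound 1 to compound 3 swaps the nitro of the ester side; both leave the amide nitrogen's aryl group untouched. There is therefore no measured guide to the size or direction of this change, only the fact that one change elsewhere was harmless and another costly. For compound 4 the expected step is a 1.3-fold higher number from compound 1 to compound 4 (0.12 log units; within the scatter), with wide uncertainty. Compound 4 is estimated at 1500 nM, in a range from 400 nM to 6000 nM.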

Compound 4, half-maximal inhibitory concentration: 3550 nM
Beside the measured number, compound 4's estimate is 2.4-fold (0.37 log units) below it, within the range that was stated.
By their numbers in this assay, from the lowest: compounds 1 and 2 (each within the scatter of the next); then compound 4; then compound 3.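

For the compounds shown here, this is the first measured change at the aryl group on the amide-type nitrogen: in this assay, replacing 4-(trifluoromethyl)phenyl with 3,4-dichlorophenyl gives a 3.1-fold higher number from compound 1 to compound 4 (0.49 log units; beyond the scatter) as a modest loss. The position is therefore not silent, since a swap between two aryl groups here moves the number beyond the usual scatter of the assay, though not by a step classed as large. Nothing measured here explains the loss, so the data give its size and direction but no reason for it.

With only one replacement shown, it remains open how a phenyl group carrying a nitrile, an amine or a carboxylic acid on this nitrogen would behave. From the compounds shown here alone, it is also open whether the same swap would give a similar step on the bromo core of compound 2.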